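Compound 3 to compound 4: an aromatic group exchange

This account rests on a few compounds, and the source may have more. Where it says the series, first, only, none or still open, it means among the compounds named here.

In a functional assay for inhibition, with Homo sapiens as the target (on this read-out higher numbers stand for weaker inhibition and lower numbers for stronger inhibition), compound 1 (`CC(C)(C)Sc1c(CC(C)(C)C(=O)O)n(Cc2ccc(Cl)cc2)c2ccc(OCc3cc4ccccc4cn3)cc12`) gives 3 nM and compound 2 (`CC(C)(C)Sc1c(CC(C)(C)C(=O)O)n(Cc2ccc(Cl)cc2)c2ccc(OCc3ccc4cnccc4n3)cc12`) gives 3 nM. Compound 3 (`CC(C)(C)Sc1c(CC(C)(C)C(=O)O)n(Cc2ccc(Cl)cc2)c2ccc(OCc3cccnc3)cc12`) gives 8 nM, the highest number of the three. Compound 4 (`CC(C)(C)Sc1c(CC(C)(C)C(=O)O)n(Cc2ccc(Cl)cc2)c2ccc(OCc3cnccn3)cc12`) has not yet been measured. Its difference from compound 3 is pyrazin-2-yl in place of pyridin-3-yl on a saturated chain carbon bound to an oxygen on an aromatic ring, with pyrazin-2-yl in place of pyridin-3-yl on a saturated chain carbon bound to an oxygen on an aromatic ring.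

Among the measured compounds shown here, the closest precedent is a nitrogen-for-carbon exchange within the aromatic group at this place, no change at the digits printed from compound 1 to compound 2 (within the scatter). The other two steps, a 2.7-fold higher number from compound 1 to compound 3 (0.43 log units; beyond the scatter) and a 2.7-fold higher number from compound 2 to compound 3 (0.43 log units; beyond the scatter), are modest and involve loss of a ring. Compound 4 keeps the single six-membered aromatic ring of compound 3, so these two steps bear on it less directly. For the measured compounds named here, no step beyond the scatter is therefore expected in this assay, although only one precedent supports this. The expected step is a 1.3-fold higher number from compound 3 to compound 4 (0.10 log units; within the scatter). For compound 4 the estimate is 10 nM, with an expected range of 4 nM to 25 nM.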

Compound 4, half-maximal inhibitory concentration: 4 nM
For compound 4 the middle estimate is 2.5-fold (0.40 log units) above the measured one, within the range that was stated.
By their numbers in this assay, from the lowest: compounds 1, 2, 4 and 3 (each within the scatter of the next, the first and the last beyond it).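

In this assay, pyrazin-2-yl in place of pyridin-3-yl gives a 2.0-fold lower number from compound 3 to compound 4 (0.30 log units; within the scatter) and so cannot be separated from no change at this position. The earlier compounds shown here left open whether a single six-membered aromatic ring could match the two-ring groups on this saturated chain carbon: compound 3 stood beyond the scatter of both, while compound 4 shows a 1.3-fold higher number from compound 1 to compound 4 (0.12 log units; within the scatter) and a 1.3-fold higher number from compound 2 to compound 4 (0.12 log units; within the scatter) with neither step beyond it. Nothing at hand accounts for these steps.

With only two single-ring groups in the series, the compounds shown do not separate the effect of the ring nitrogens' number from that of their arrangement. From the compounds shown here alone, whether pyrimidin-5-yl, pyridin-2-yl, plain phenyl or a saturated ring such as morpholine would stay in this range remains open.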